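Methyl Placement and Tolerated Concentration in a Small Series

The compounds below may be only part of what the source reports. "The series", "measured", "known", "first", "only" and "open" are said of these compounds alone.

Three compounds have been measured in an ADME assay on MT4 cells (Homo sapiens) for cytotoxicity, read by MTT assay, with a stated time of 4 days; a higher number here means that more compound is tolerated, a lower number that less compound is tolerated:
compound 1, `Cc1cccc(OCCn2ccc(=O)n(Cc3ccccc3)c2=O)c1`, 207000 nM;
compound 2, `Cc1ccc(OCCn2ccc(=O)n(Cc3ccccc3)c2=O)cc1`, 187000 nM;
compound 3, `Cc1cc(C)cc(OCCn2ccc(=O)n(Cc3ccccc3)c2=O)c1`, 46000 nM.

Compound 1 and compound 2 share a core that differs as 4-methylphenyl in place of 3-methylphenyl on an oxygen on a saturated carbon, and this gives a 1.1-fold lower number from compound 1 to compound 2 (0.04 log units; within the scatter). The change methyl in place of hydrogen on an aromatic carbon made the step of a 4.5-fold lower number from compound 1 to compound 3 (0.65 log units; beyond the scatter). Compound 4, `Cc1ccc(OCCn2cc(C)c(=O)n(Cc3ccccc3)c2=O)cc1`, is not yet measured; it differs from compound 2 by methyl in place of hydrogen on an aromatic carbon. For the measured compounds named here, this is the same kind of change as the one from compound 1 to compound 3, but the place differs: there the methyl entered a six-membered aromatic ring of carbon only, meta to a large group and meta to a methyl group, whereas here it enters a six-membered aromatic ring with 2 nitrogen, ortho to a group of 1 heavy atom and meta to a benzyl group. The expected step is a 1.6-fold lower number from compound 2 to compound 4 (0.19 log units; within the scatter), resting on compound 1 with a 4.5-fold lower number from compound 1 to compound 3 (0.65 log units; beyond the scatter), weighed against the different place. Compound 4 is estimated at 120000 nM, expected between 50000 nM and 250000 nM.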

Compound 4, half-maximal cytotoxic concentration: > 356000 nM
Compound 4: only a limit was reported (the forecaster's own chance of this, stated with the estimate: 10%); middle value at least 2.9-fold (0.47 log units) away from the limit.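

Compound 4 gives only a limit, > 356000 nM, and not an exact number. In this assay, methyl in place of hydrogen on an aromatic carbon gives an at least 1.9-fold higher number from compound 2 to compound 4 (0.27 log units; that floor lies within the scatter), so this change does not carry over as one fixed step from one core to another: the same change on two cores in this assay, a 4.5-fold lower number (0.65 log units; beyond the scatter) from compound 1 to compound 3 and an at least 1.9-fold higher number (0.27 log units; that floor lies within the scatter) from compound 2 to compound 4, at least 8.5-fold (0.93 log units) apart, beyond the scatter of two such steps

This rests on a single pair for each core, with the methyl entering a different ring in each, so it does not show which of these differences accounts for the gap, nor how far compound 4 truly lies from compound 2. The compounds shown leave open whether an ethyl group or a chlorine atom at this place would give a similar step. They also leave open what this methyl would do on the core of compound 1.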